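Lengthening the bromoalkyl chain on the shared core

A few compounds are considered here, and "the series" means these few. Any claim that something is new, unique, unknown or untested is made for them only; others in the source may bear on it.

In a functional assay on U-937 cells (Homo sapiens) for cytotoxicity, read by MTT assay, with a stated time of 24 h (on this read-out lower numbers stand for stronger inhibition and higher numbers for weaker inhibition), two compounds have been measured so far. Compound 1 `CC(C)(C)OC(=O)N1CCCN(CCCCCOc2c(Br)cc(Br)cc2Oc2ccc(Br)cc2Br)CC1` gives 39.5 ug/mL and compound 2 `BrCCCOc1c(Br)cc(Br)cc1Oc1ccc(Br)cc1Br` gives 30.3 ug/mL. Compound 2 thus has the lowest number of the pair, but the two values lie within the usual scatter of each other, so the data do not separate them.

The next compound is compound 3 `BrCCCCOc1c(Br)cc(Br)cc1Oc1ccc(Br)cc1Br`, which departs from compound 2 by bromomethyl in place of bromo on a saturated chain carbon, three bonds along the chain from an oxygen on an aromatic ring. This places bromomethyl in place of bromo on a saturated chain carbon, three bonds along the chain from an oxygen on an aromatic ring. Read one way, the same difference is 3-bromopropyl to 4-bromobutyl.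

Among the measured compounds shown here, no measured pair differs in one place, so there is no direct precedent for this step. For the measured compounds named here, the only guide is that the quite different side chains of compound 1 at 39.5 ug/mL and compound 2 at 30.3 ug/mL remain within the scatter. No shift beyond the scatter is expected in this assay, and no direction is favoured. The expected change is a 1.0-fold lower number from compound 2 to compound 3 (0.02 log units; within the scatter). For compound 3 the estimated value is 29 ug/mL, with an expected range of 14 ug/mL to 55 ug/mL.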

Compound 3, half-maximal inhibitory concentration: 29 ug/mL
Compound 3: the middle estimate sits on the measured number at the digits printed; low and high end bracket the measured number.
By their numbers in this assay, from the lowest: compounds 3, 2 and 1 (each within the scatter of the next).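

Working notes on the bromoalkyl chain: in this assay, going from 3-bromopropyl to 4-bromobutyl on the shared core, with bromomethyl in place of bromo on a saturated chain carbon, three bonds along the chain from an oxygen on an aromatic ring, comes with a 1.0-fold lower number from compound 2 to compound 3 (0.02 log units; within the scatter) and so gives the series its first reading of a single change. Compounds 1 and 2 differ in more than one place and could not show this, whereas the present pair shows that one added carbon at this place leaves the read-out within the scatter and gives this step no direction. No supporting measurement on these compounds is available to account for this result.

This single step cannot show whether a longer chain, such as 5-bromopentyl or 6-bromohexyl, would also stay within the scatter in this assay or would move the number beyond it. Also open, as far as these compounds go, is whether an amine, a carboxylic acid or a hydroxyl group in place of the bromo on the 4-bromobutyl chain would leave the number similarly unmoved.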